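The source may hold more compounds than are shown below. What is called first, only, known or untested is meant among the compounds shown, and "the series" means these compounds.

Compound 3 `CCOC(=O)CC1C(C(=O)OCC)=C(N)Oc2ccc(-c3cccc(F)c3)cc21` gives 76400 nM in a functional assay on HL-60 cells (Homo sapiens) for cytotoxicity, read by CellTiter-Blue, with a stated time of 48 h (on this read-out lower numbers stand for stronger inhibition and higher numbers for weaker inhibition), the highest number among the three compounds measured. Its nearest neighbour is compound 2 `CCCCOC(=O)CC1C(C(=O)OCCCC)=C(N)Oc2ccc(-c3cc(OC)cc(OC)c3)cc21`, which gives 32000 nM, a gap beyond the scatter; furthest from it lies compound 1 `COC(=O)CC1C(C(=O)OC)=C(N)Oc2ccc(-c3cc(OC)cc(OC)c3)cc21` at 2420 nM, also beyond the scatter. Compound 4 `CCOC(=O)CC1C(C(=O)OCC)=C(N)Oc2ccc(-c3ccnc(OC)c3)cc21` has not yet been measured. It differs from compound 3 in one place: 2-methoxypyridin-4-yl in place of 3-fluorophenyl on an aromatic carbon. Within the data shown here, no measured pair shares this change, so the size of the step can only be expected, not read from the data. Given that compound 1 gives 2420 nM, the only methoxy-bearing compound here, compound 4 is expected to move toward a modestly lower number, with a 2.5-fold lower number from compound 3 to compound 4 (0.41 log units; beyond the scatter) as the estimated step. Compound 4 is estimated at 30000 nM, within a range of 8000 nM to 100000 nM.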

Compound 4, half-maximal inhibitory concentration: 10200 nM
For compound 4 the middle estimate is 2.9-fold (0.47 log units) above the measured one, within the range that was stated.
By their numbers in this assay, from the lowest: compound 1; then compound 4; then compound 2; then compound 3.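

In this assay, putting 2-methoxypyridin-4-yl in place of 3-fluorophenyl on the aromatic carbon gives a 7.5-fold lower number from compound 3 to compound 4 (0.87 log units; beyond the scatter) with the ethyl esters unchanged. This is the first single-place comparison among these compounds, and it shows that the number responds to the group carried at this position. Nothing measured here accounts for the size of the step. As far as these compounds go, what a plain pyridin-4-yl or a 3-methoxyphenyl would give at this position remains open, so the step cannot yet be divided between the ring nitrogen and the methoxy group.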